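Swapping a Cyclohexyloxy Group for a Thioether Chain

The source may hold more compounds than are shown below. What is called first, only, known or untested is meant among the compounds shown, and "the series" means these compounds.

Measured so far in an assay on cells for antagonist activity at transient receptor potential cation channel subfamily V member 1 (Homo sapiens), read by FLIPR and calcium flux, with a stated time of 6 min; on this read-out higher numbers stand for weaker inhibition and lower numbers for stronger inhibition:
Compound 1 `CCCCOc1nc(C(C)(C)C)ccc1CNC(=O)C(C)c1ccc(NS(C)(=O)=O)c(F)c1` gives 0.9 nM.
Compound 2 `CCCCCCOc1nc(C(C)(C)C)ccc1CNC(=O)C(C)c1ccc(NS(C)(=O)=O)c(F)c1` gives 2.7 nM.
Compound 3 `CC(C(=O)NCc1ccc(C(C)(C)C)nc1OC1CCCCC1)c1ccc(NS(C)(=O)=O)c(F)c1` gives 2.5 nM.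

Compound 3 stands second highest of these three numbers; it sits within the scatter of compound 2, while compound 1 lies further off, as shown by a 2.8-fold higher number from compound 1 to compound 3 (0.44 log units; beyond the scatter).

Compound 4 `CC(C(=O)NCc1ccc(C(C)(C)C)nc1SCCCN1CCCC1)c1ccc(NS(C)(=O)=O)c(F)c1` differs from compound 3 in one place: (3-(pyrrolidin-1-yl)propyl)sulfanyl in place of cyclohexyloxy on an aromatic carbon. The measured steps that bear on this are those changing the group on the same aromatic oxygen, a 2.8-fold higher number from compound 1 to compound 3 (0.44 log units; beyond the scatter) and a 1.1-fold lower number from compound 2 to compound 3 (0.03 log units; within the scatter), both modest or within the scatter. Among the compounds with values here, no measured step introduces sulfur or a nitrogen-containing ring, so the expectation is uncertain. Only a modest step is expected, a 2.0-fold higher number from compound 3 to compound 4 (0.30 log units; within the scatter). Compound 4 is therefore estimated at 5 nM, ranging from 1.5 nM to 20 nM.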

Compound 4, inhibition constant: 17.1 nM
Beside the measured number, compound 4's estimate is 3.4-fold (0.53 log units) below it; low and high end bracket the measured number.
By their numbers in this assay, from the lowest: compound 1; then compounds 3 and 2 (each within the scatter of the next); then compound 4.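

In this assay, the sulfur-linked (3-(pyrrolidin-1-yl)propyl)sulfanyl group gives weaker inhibition than any of the three oxygen-linked groups: a 6.8-fold higher number from compound 3 to compound 4 (0.84 log units; beyond the scatter), a 6.3-fold higher number from compound 2 to compound 4 (0.80 log units; beyond the scatter) and a 19-fold higher number from compound 1 to compound 4 (1.28 log units; beyond the scatter). The last of these is the largest step seen so far at this position, so the position responds more strongly to this change than to swapping one oxygen-linked group for another. No measurement shown here explains the shift.

From the compounds shown here alone, the linking atom and the chain change together, so their separate contributions remain unknown. A butylsulfanyl group, or the same pyrrolidine chain joined through oxygen, would help separate them.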